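Swapping the amide ring

This account rests on a few compounds, and the source may have more. Where it says the series, first, only, none or still open, it means among the compounds named here.

Of the compounds shown here, two have been measured so far. Compound 1 `O=C(c1ccc(-c2ccc3ncc(-c4ccc5cnccc5c4)n3c2)cc1)N1CCC(N2CCCCC2)CC1` gives 92.9% in an assay on Sf21 cells for inhibition of MAP kinase-interacting serine/threonine-protein kinase 1 (Homo sapiens), read by luminescence and ADP-Glo, with stated times of 10 min and 40 min, tested at 500 nM; a higher number here means more inhibition at the concentration tested (going by the name of the read-out), a lower number less inhibition. For the measured compounds named here, compound 2 `O=C(c1ccc(-c2ccc3ncc(-c4ccc5ncccc5c4)n3c2)cc1)N1CCC(N2CCCCC2)CC1` gives 62.8% in this assay; this is the lower of the two numbers, and the only measured step, a number 30.1 percentage points lower from compound 1 to compound 2 (beyond the scatter), separates it from compound 1, which carries isoquinolin-6-yl where compound 2 carries quinolin-6-yl.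

Compound 3 `O=C(c1ccc(-c2ccc3ncc(-c4ccc5ncccc5c4)n3c2)cc1)N1CCOCC1` has not been measured. It differs from compound 2 in one place: morpholin-4-yl in place of 4-(piperidin-1-yl)piperidin-1-yl on a carbonyl carbon. This change sits on the carbonyl carbon, far from the aromatic position that was altered between compound 1 and compound 2. Going by the values given here, no measured step therefore bears on it, and there is nothing among the measured compounds that shows how the amide ring affects the number in this assay. The step of a number 12.8 percentage points lower from compound 2 to compound 3 (beyond the scatter) is an estimate made without such guidance, so the range must be wide. For compound 3 the expected value in this assay is 50%, with a range from 20% to 80%.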

Compound 3, a percentage reported as inhibition, at one concentration (the size of the read-out at that concentration, not a potency): 74.7%
The estimate for compound 3 lay 24.7 percentage points below the measured number, and the stated range covers the measured number.
By their numbers in this assay, from the lowest: compound 2; then compound 3; then compound 1.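

For the compounds shown here, this is the first measured change on the carbonyl carbon, and it shows that the group there affects the number: in this assay the swap to morpholin-4-yl gives a number 11.9 percentage points higher from compound 2 to compound 3 (beyond the scatter) with quinolin-6-yl held in place. The larger 4-(piperidin-1-yl)piperidin-1-yl, with 12 heavy atoms and two rings, is thus not required for inhibition at the tested concentration in this pair, and morpholin-4-yl, with 6 heavy atoms and one ring, gives the higher number. Nothing available explains this rise, so the step stands as an observation without a known cause.

Going by these compounds alone, only two groups on the carbonyl carbon can be compared here, both with quinolin-6-yl, so it remains open whether the same swap would shift the number in the same direction and by a similar amount with isoquinolin-6-yl, the group carried by compound 1. Also open, from the compounds shown here alone, is how a piperazin-1-yl ring, which has a second nitrogen in place of the oxygen of morpholin-4-yl, or a simple open-chain dimethylamino group would read in this assay at this position.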